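Moving the methyl group from 3-methylphenyl to 2-methylphenyl

A few compounds are considered here, and "the series" means these few. Any claim that something is new, unique, unknown or untested is made for them only; others in the source may bear on it.

Of the compounds shown here, two built on the same core have so far been measured in a functional assay on B16 cells (Mus musculus), read by spectrophotometry, with a stated time of 3 days; on this read-out lower numbers stand for stronger inhibition and higher numbers for weaker inhibition. There, compound 1 (`Cc1ccc(NC(=S)N/N=C/c2cccc3ccccc23)cc1`) gives 580 nM, and compound 2 (`Cc1cccc(NC(=S)N/N=C/c2cccc3ccccc23)c1`) gives 450 nM. Among the compounds with values here, compound 2 therefore stands within the scatter of compound 1, the only other compound with a number.

Compound 3 (`Cc1ccccc1NC(=S)N/N=C/c1cccc2ccccc12`) has the same atoms as compound 2, joined differently: 2-methylphenyl in place of 3-methylphenyl on an amide-type nitrogen. Within the data shown here, only one measured step bears on this change. It is a 1.3-fold lower number from compound 1 to compound 2 (0.11 log units; within the scatter), which exchanged 3-methylphenyl for 4-methylphenyl at the same place. Among the measured compounds shown here, no measured compound carries 2-methylphenyl, so this single step is a limited guide and the range must stay wide. In this assay, the expected step is a 1.1-fold higher number from compound 2 to compound 3 (0.05 log units; within the scatter), and no change beyond the scatter is expected. For compound 3, the estimated value is 500 nM, with an expected range from 200 nM to 1200 nM.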

Compound 3, half-maximal inhibitory concentration: 490 nM
For compound 3 the middle estimate is 1.0-fold (0.01 log units) above the measured one; the measured number falls inside the stated range.
By their numbers in this assay, from the lowest: compounds 2, 3 and 1 (each within the scatter of the next).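

In this assay, 2-methylphenyl on the amide-type nitrogen now joins 3-methylphenyl and 4-methylphenyl at the same place: replacing 3-methylphenyl gives a 1.1-fold higher number from compound 2 to compound 3 (0.04 log units; within the scatter), and replacing 4-methylphenyl gives a 1.2-fold lower number from compound 1 to compound 3 (0.07 log units; within the scatter). Within the data shown here, the earlier pair compared only two of these methylphenyl groups, whereas compound 1, compound 2 and compound 3 together show that, across these three groups, moving the methyl around the phenyl ring leaves the numbers within the scatter of each other. Nothing available explains why these three groups cannot be told apart in this read-out.

All three compounds carry a methyl group on that phenyl ring, so these data do not show what the methyl itself contributes, or whether a plain phenyl would give a number like theirs. On these data alone, it also remains open whether a different group on the ring, such as methoxy, chloro or a carboxylic acid, or a longer chain such as propyl in place of the methyl, would move the number beyond the scatter.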